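Hydroxymethyl in place of isopropyl on an aromatic nitrogen

The source may hold more compounds than are shown below. What is called first, only, known or untested is meant among the compounds shown, and "the series" means these compounds.

Measured in a functional assay on KB cells (Homo sapiens) for inhibition, with a stated time of 72 h; on this read-out higher numbers stand for weaker inhibition and lower numbers for stronger inhibition:
- compound 1 `COc1cc(C(=O)c2ccc3[nH]ccc3c2)cc(OC)c1OC`: 104 nM
- compound 2 `COc1cc(C(=O)c2ccc3c(ccn3C(C)C)c2)cc(OC)c1OC`: 1800 nM

Of these two numbers, compound 2 has the higher, at 1800 nM. Compound 3 `COc1cc(C(=O)c2ccc3c(ccn3CO)c2)cc(OC)c1OC` differs from it by hydroxymethyl in place of isopropyl on an aromatic nitrogen. Among the compounds with values here, one measured step bears on this change: a 17-fold higher number from compound 1 to compound 2 (1.24 log units; beyond the scatter), a large step beyond the scatter, made at that same nitrogen. Hydroxymethyl is not hydrogen, so only part of that step is expected to be regained in this assay, towards a lower number. The expected step is a 3.6-fold lower number from compound 2 to compound 3 (0.56 log units; beyond the scatter). The estimate for compound 3 is 500 nM, with an expected range of 130 nM to 2000 nM.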

Compound 3, half-maximal inhibitory concentration: 39 nM
For compound 3 the middle estimate is 13-fold (1.11 log units) above the measured one, outside the stated range (below it).
By their numbers in this assay, from the lowest: compound 3; then compound 1; then compound 2.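

In this assay, a substituent on this aromatic nitrogen does not by itself weaken inhibition, as the isopropyl compound alone might have suggested. Hydroxymethyl gives a 46-fold lower number from compound 2 to compound 3 (1.66 log units; beyond the scatter) and also a 2.7-fold lower number from compound 1 to compound 3 (0.43 log units; beyond the scatter) in a modest step, so it goes beyond the compound with hydrogen at this nitrogen, and the identity of the group sets the direction of the change. Nothing available here explains why these groups differ. The compounds shown leave open whether the oxygen or the small size of hydroxymethyl matters more. Methyl, methoxymethyl, hydroxyethyl or aminomethyl on the same nitrogen would bear on that question.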